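A few compounds are considered here, and "the series" means these few. Any claim that something is new, unique, unknown or untested is made for them only; others in the source may bear on it.

Measured so far in an assay on cells for displacement of a labelled ligand from adenosine receptor A3 (Homo sapiens), read by scintillation counting and radioligand binding, with a stated time of 180 min, tested at 10 uM; a higher number here means more inhibition at the concentration tested (going by the name of the read-out), a lower number less inhibition:

Compound 1 `Cn1cnc2c(N3CCCCC3)nc(-c3ccccc3O)nc21`: 20%
Compound 2 `CN1CCN(c2nc(-c3cccc(O)c3)nc3c2ncn3C)CC1`: 63.8%
Compound 3 `Clc1ccc(-c2nc(N3CCCCC3)c3nc[nH]c3n2)cc1Cl`: > 80% (a limit)

Compound 2, with its 3-hydroxyphenyl group and 4-methylpiperazin-1-yl group, gives 63.8% in this assay, the higher of the two plain numbers reported. Compound 1 gives 20%, a gap from compound 2 that lies beyond the usual scatter of this measurement. Compound 3 is reported only as a limit, > 80%, so no number is known for it. That ceiling is the limit of > 80% in this assay, at which 1 of the 3 values shown sits.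

Compound 4 `CN1CCN(c2nc(-c3ccc(Cl)c(Cl)c3)nc3c2ncn3C)CC1` has not yet been measured. It differs from compound 2 in one place: 3,4-dichlorophenyl in place of 3-hydroxyphenyl on an aromatic carbon. Going by the values given here, no pair of measured compounds differs by exactly this change, so no measured step is available. What can be said is that compound 3, which also carries a 3,4-dichlorophenyl group though on a different core, reached the limit of the assay, while compound 2 with its 3-hydroxyphenyl group did not. On that slender basis a rise rather than a fall is expected, of a size somewhat beyond the scatter, with a real chance that only a limit is reported.

Compound 4 is expected to give 76%, with a likely range from 55% to 92%. The expected step is a number 12.2 percentage points higher from compound 2 to compound 4 (beyond the scatter).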

Compound 4, a percentage reported as inhibition, at one concentration (the size of the read-out at that concentration, not a potency): 35.3%
Compound 4: middle estimate off by 40.7 percentage points, on the high side; measured number outside the range, below it.
By their numbers in this assay, from the lowest: compound 1; then compound 4; then compound 2. At a limit, above all of these: compound 3.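

In this assay, the aromatic carbon between two ring nitrogen atoms now has its first measured step, with the 4-methylpiperazin-1-yl group held constant: 3,4-dichlorophenyl in place of 3-hydroxyphenyl gives a number 28.5 percentage points lower from compound 2 to compound 4 (beyond the scatter). This single change removes the hydrogen-bond donor and acceptor of the 3-hydroxyphenyl group and brings in chlorine at the same time, and one step cannot separate these two parts of the change. Compound 3 differs from compound 4 in more than one place and remains a limit, which leaves it with no bearing on this step: the limit of > 80% in this assay, at which 1 of the 4 values shown sits.

The compounds shown leave open whether a 3-methoxyphenyl or an unsubstituted phenyl group at this position would read closer to compound 2 or to compound 4, which would help show whether the hydroxyl group or the chlorine atoms matter more here. They also leave open whether the same swap would run in the same direction with a morpholine in place of the 4-methylpiperazin-1-yl group.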